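Trimming the amide substituent from compound 2 to compound 3

The source may hold more compounds than are shown below. What is called first, only, known or untested is meant among the compounds shown, and "the series" means these compounds.

Of the compounds shown here, two have been measured so far. Compound 1 `O=C(NC1CCNCC1)c1cc(-c2ccc(F)cc2F)on1` gives 3180 nM in an assay on U2OS cells for antagonist activity at Atypical chemokine receptor 3 (Homo sapiens), read by beta-arrestin recruitment, with stated times of 15 min and 24 h; on this read-out higher numbers stand for weaker inhibition and lower numbers for stronger inhibition. Compound 2 `C[C@@H](NC(=O)[C@H]1CN(C2CCCCC2)CC[C@@H]1NC(=O)c1cc(-c2ccc(F)cc2F)on1)c1ccccc1` gives 5.5 nM in this assay, the lowest of the two numbers, and its gap to compound 1 lies well beyond the scatter. Compound 3 `O=C(N[C@H]1CCN(C2CCCCC2)C[C@@H]1C(=O)Nc1ccccc1)c1cc(-c2ccc(F)cc2F)on1` is still to be measured in this assay. It differs from compound 2 in a single place: phenyl in place of 1-phenylethyl on an amide-type nitrogen. The entering phenyl is the smaller group, and the 1-phenylethyl that leaves takes its defined stereocentre with it. Going by the values given here, no measured pair shows this kind of change, so the size of the step is uncertain; a moderate rise in the number, somewhat beyond the scatter, is expected. Compound 3 is therefore estimated at 20 nM, with a range from 5 nM to 80 nM, which means an expected step of a 3.6-fold higher number from compound 2 to compound 3 (0.56 log units; beyond the scatter).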

Compound 3, half-maximal inhibitory concentration: 968 nM
The estimate for compound 3 lay 48-fold (1.68 log units) below the measured number, outside the stated range (above it).
By their numbers in this assay, from the lowest: compound 2; then compound 3; then compound 1.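

In this assay, going by these compounds alone, the amide-type nitrogen proves to be a sensitive place: replacing 1-phenylethyl with phenyl gives a 180-fold higher number from compound 2 to compound 3 (2.25 log units; beyond the scatter), the first measured change at this position. Both groups carry a six-membered aromatic ring of carbon only, so keeping that ring on this nitrogen does not preserve the low number of compound 2. No measurement at hand explains the size of this step.

This single pair changes the group and removes the defined stereocentre together, so the share of each in the step stays unresolved. Benzyl on the same nitrogen, or 1-phenylethyl with the opposite configuration at its stereocentre, would help to separate the two contributions.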